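Working notes on the unsubstituted analogue of compound 2

The compounds below may be only part of what the source reports. "The series", "measured", "known", "first", "only" and "open" are said of these compounds alone.

Measured in a functional assay on HL-60 cells (Homo sapiens) for antiproliferative activity, read by sulforhodamine B assay, with a stated time of 72 h; on this read-out higher numbers stand for weaker inhibition and lower numbers for stronger inhibition:
compound 1 `COc1ccc(C)cc1NC(=S)N/N=C/c1ccc2ccccc2n1`: > 100000 nM
compound 2 `Cc1cccc(NC(=S)N/N=C/c2ccc3ccccc3n2)c1`: > 100000 nM
compound 3 `NC(=S)N/N=C/c1ccc2cccnc2n1`: > 100000 nM

Each of these three values is a limit of the assay, not a number. Compound 2 therefore stands at the limit of > 100000 nM in this assay, at which 3 of the 3 values shown sit, with no number of its own. Among the measured compounds shown here, the only single-change step among the measured compounds, a step that the two limits leave unreadable from compound 1 to compound 2, touches compound 2 but gives no size. Compound 4 `NC(=S)N/N=C/c1ccc2ccccc2n1` differs from compound 2 by hydrogen in place of 3-methylphenyl on an amide-type nitrogen. For the measured compounds named here, no measured step of this kind exists. Compound 3 carries the same hydrogen on the amide-type nitrogen on a different core and also gives a limit. Nothing here points beyond the scatter, so compound 4 is expected to show a number no higher from compound 2 to compound 4 (the limit leaves the size open). Compound 4 is estimated at 100000 nM, between 30000 nM and 300000 nM, most likely reported as a further limit.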

Compound 4, half-maximal inhibitory concentration: > 100000 nM
Compound 4 was reported as a limit; the forecaster's own chance of this, stated with the estimate: 85%; the middle value lies on the limit itself.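

Compound 2 and compound 4 are both reported only as limits in this assay, so the step between them cannot be read. The compounds shown leave open whether hydrogen or 3-methylphenyl on the amide-type nitrogen makes any difference to activity.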